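Working notes: one substituent exchange starting from compound 3

The source may hold more compounds than are shown below. What is called first, only, known or untested is meant among the compounds shown, and "the series" means these compounds.

Measured in a functional assay on CWR22R cells (Homo sapiens) for antiproliferative activity, read by propidium iodide staining, with a stated time of 96 h (on this read-out higher numbers stand for weaker inhibition and lower numbers for stronger inhibition), so far:
- compound 1 (`CC(O)(COc1cccc(S(F)(F)(F)(F)F)c1)C(=O)Nc1ccc([N+](=O)[O-])cc1C(F)(F)F`) gives 15500 nM
- compound 2 (`CC(O)(COc1ccc(C#N)cc1)C(=O)Nc1ccc(S(F)(F)(F)(F)F)cc1`) gives 26100 nM
- compound 3 (`CC(O)(CS(=O)(=O)c1ccc(S(F)(F)(F)(F)F)cc1)C(=O)Nc1ccc(S(F)(F)(F)(F)F)cc1`) gives 17300 nM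

Compound 3 at 17300 nM is the middle one of the three numbers, within the scatter of both compound 1 and compound 2. Compound 4 (`CC(O)(CS(=O)(=O)c1ccc(OC(F)(F)F)cc1)C(=O)Nc1ccc(S(F)(F)(F)(F)F)cc1`) has trifluoromethoxy in place of the group of 6 heavy atoms, on an aromatic carbon, para to a large group (a group of 5 heavy atoms (1 carbon, 1 oxygen, 3 fluorine; no ring) in place of a group of 6 heavy atoms (5 fluorine, 1 sulfur; no ring), on an aromatic carbon). Within the data shown here, no measured pair isolates this change, and no step beyond the scatter is expected in this assay for it. This expectation rests only on compound 1 at 15500 nM and compound 2 at 26100 nM lying within the scatter of compound 3 despite their other structural differences. The estimated step is a 1.2-fold higher number from compound 3 to compound 4 (0.06 log units; within the scatter) and stays within the scatter. Compound 4 is expected at 20000 nM with an estimated range from 9000 nM to 40000 nM in this read-out.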

Compound 4, half-maximal inhibitory concentration: 51900 nM
The estimate for compound 4 lay 2.6-fold (0.41 log units) below the measured number, outside the stated range (above it).
By their numbers in this assay, from the lowest: compounds 1, 3, 2 and 4 (each within the scatter of the next, the first and the last beyond it).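

In this assay, among these compounds, trifluoromethoxy in place of the group of 6 heavy atoms, on an aromatic carbon para to a large group, gives a 3.0-fold higher number from compound 3 to compound 4 (0.48 log units; beyond the scatter) and thus the first single-place comparison. Among the compounds shown here, the read-out therefore responds to a change at this position, which the earlier compounds, differing in several places, could not show. No available data bear on the reason for this step.

Still open, on these data alone, is how an amine or a carboxylic acid on this aromatic carbon would read. One exchange also leaves open whether the same step would appear on another core.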